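The compounds below may be only part of what the source reports. "The series", "measured", "known", "first", "only" and "open" are said of these compounds alone.

Of the compounds shown here, three built on one shared core have been measured in an assay on CHO cells for antagonist activity at transient receptor potential cation channel subfamily V member 1 (Homo sapiens), read by FLIPR and calcium flux; on this read-out higher numbers stand for weaker inhibition and lower numbers for stronger inhibition. Compound 1 `CC(C(=O)NCc1ccc(C(F)(F)F)nc1Br)c1ccc(NS(C)(=O)=O)c(F)c1` gives 169 nM in this assay. Compound 2 `CCCc1nc(C(F)(F)F)ccc1CNC(=O)C(C)c1ccc(NS(C)(=O)=O)c(F)c1` gives 22.7 nM in this assay. Compound 3 `CCC1CCC(c2nc(C(F)(F)F)ccc2CNC(=O)C(C)c2ccc(NS(C)(=O)=O)c(F)c2)CC1` gives 0.3 nM in this assay, the lowest of the three numbers, with compound 2 nearest and compound 1 furthest from it. The steps that lead to compound 3 are a 560-fold lower number from compound 1 to compound 3 (2.75 log units; beyond the scatter) and a 76-fold lower number from compound 2 to compound 3 (1.88 log units; beyond the scatter), and the step between the other two is a 7.4-fold lower number from compound 1 to compound 2 (0.87 log units; beyond the scatter).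

Compound 4 `CC(C(=O)NCc1ccc(C(F)(F)F)nc1C1=C[C@H](C)CCC1)c1ccc(NS(C)(=O)=O)c(F)c1` is not yet measured. It differs from compound 3 in one place: 3-methylcyclohex-1-en-1-yl in place of 4-ethylcyclohexyl on an aromatic carbon. Both steps toward compound 3 showed that a six-membered non-aromatic carbon ring at this position lowers the number strongly, so the ring itself is kept here; what changes is the loss of one carbon and the arrival of a double bond outside aromatic rings. Compound 4 is therefore expected to stay well below compound 2, but a moderate rise from compound 3 is expected, a 5.0-fold higher number from compound 3 to compound 4 (0.70 log units; beyond the scatter). The estimate for compound 4 in this assay is 1.5 nM, with a range from 0.4 nM to 6 nM.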

Compound 4, inhibition constant: 0.1 nM
Compound 4: the middle estimate sits 15-fold (1.18 log units) above what was measured, and the stated range ends above it.
By their numbers in this assay, from the lowest: compound 4; then compound 3; then compound 2; then compound 1.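

In this assay, at the aromatic carbon next to the ring nitrogen, 3-methylcyclohex-1-en-1-yl goes beyond what 4-ethylcyclohexyl reached, with a 3.0-fold lower number from compound 3 to compound 4 (0.48 log units; beyond the scatter), so neither the ethyl group nor a fully saturated ring is required for the lowest number seen here. The same group gives a 230-fold lower number from compound 2 to compound 4 (2.36 log units; beyond the scatter) in place of propyl and a 1700-fold lower number from compound 1 to compound 4 (3.23 log units; beyond the scatter) in place of bromo, the widest steps yet seen at this position. No evidence at hand explains the gain from this change.

Going by these compounds, compound 4 differs from compound 3 in the double bond, in methyl for ethyl and in where that group sits on the ring, so the share of each stays open. The compounds shown also leave open how a saturated 3-methylcyclohexyl group, the opposite stereoisomer of compound 4 or a ring bearing an amine would read in this assay.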